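The source may report more compounds than this note shows. Statements on the series, on what has been measured and on what is new or still open speak of the compounds shown alone.

In an assay on HEK293 cells for positive allosteric modulation of metabotropic glutamate receptor 5 (Homo sapiens), read by FLIPR, with a stated time of 1 h (a higher number here means that more compound is needed for the effect, a lower number that less compound is needed), the measured compounds stand as follows:

compound 1 `O=C(C1CCCCC1)N1CCc2nc(C#Cc3ccccc3)sc2C1` gives 167 nM;
compound 2 `CC1CCC(C(=O)N2CCc3nc(C#Cc4ccccc4)sc3C2)CC1` gives 190 nM;
compound 3 `O=C(c1cccc(Cl)c1)N1CCc2nc(C#Cc3ccccc3)sc2C1` gives 8.7 nM.

Compound 3 has the lowest number of the three. Both steps leading to it are large: a 19-fold lower number from compound 1 to compound 3 (1.28 log units; beyond the scatter) and a 22-fold lower number from compound 2 to compound 3 (1.34 log units; beyond the scatter). By contrast a 1.1-fold higher number from compound 1 to compound 2 (0.06 log units; within the scatter), so the methyl on the saturated ring changes nothing beyond the scatter. Compound 4 `O=C(N1CCCCC1)N1CCc2nc(C#Cc3ccccc3)sc2C1` differs from compound 3 in one place: piperidin-1-yl in place of 3-chlorophenyl on a carbonyl carbon. Within the data shown here, no measured step makes this exact change. Among the measured compounds shown here, the steps that bear on it are those in which a six-membered non-aromatic ring on the carbonyl carbon, in compound 1 and compound 2, is replaced by 3-chlorophenyl. Piperidin-1-yl is again a six-membered non-aromatic ring, so the expected step is back toward the numbers of compound 1 and compound 2, and it is expected to be large. The estimate for compound 4 is a step of a 17-fold higher number from compound 3 to compound 4 (1.24 log units; beyond the scatter). Compound 4 is thus expected to give 150 nM, within a range of 40 nM to 600 nM.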

Compound 4, half-maximal effective concentration: 75 nM
Compound 4: middle estimate off by 2.0-fold (0.30 log units), on the high side, within the range that was stated.
By their numbers in this assay, from the lowest: compound 3; then compound 4; then compounds 1 and 2 (each within the scatter of the next).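

In this assay, the six-membered non-aromatic rings on this carbonyl carbon are not interchangeable: with piperidin-1-yl in place of cyclohexyl there is a 2.2-fold lower number from compound 1 to compound 4 (0.35 log units; beyond the scatter), and with piperidin-1-yl in place of 4-methylcyclohexyl there is a 2.5-fold lower number from compound 2 to compound 4 (0.40 log units; beyond the scatter). Even so, 3-chlorophenyl keeps the lowest number of the four compounds, as an 8.6-fold higher number from compound 3 to compound 4 (0.94 log units; beyond the scatter) shows, so piperidin-1-yl recovers only part of the difference between 3-chlorophenyl and the cyclohexyl rings. Nothing available explains why piperidin-1-yl and cyclohexyl differ at this place.

The compounds shown leave open how a second ring hetero atom, as in morpholin-4-yl or piperazin-1-yl, or an open-chain amine such as diethylamino, would behave on this carbonyl carbon. They also leave open how much of the low number of compound 3 depends on the chlorine, which unsubstituted phenyl would test.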